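The compounds below may be only part of what the source reports. "The series", "measured", "known", "first", "only" and "open" are said of these compounds alone.

Measured so far:
- compound 1, `COc1cccc(OS(=O)(=O)c2ccc(N3CCN(C)C3=O)cc2)c1`: 1600 nM
- compound 2, `COc1ccc(OS(=O)(=O)c2ccc(N3CCN(C)C3=O)cc2)cc1OC`: 8500 nM

In a functional assay on M21 cells (Homo sapiens) for antiproliferative activity, read by sulforhodamine B assay, with a stated time of 48 h (a higher number here means a weaker inhibitor, a lower number a stronger inhibitor), compound 1 gives the lower of the two numbers, with compound 2 as the nearest neighbour at a 5.3-fold higher number from compound 1 to compound 2 (0.73 log units; beyond the scatter). For the measured compounds named here, the single measured step, methoxy in place of hydrogen on an aromatic carbon, therefore weakens inhibition modestly.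

Compound 3, `CN1CCN(c2ccc(S(=O)(=O)Oc3ccc(Cl)cc3)cc2)C1=O`, differs from compound 1 by 4-chlorophenyl in place of 3-methoxyphenyl on an oxygen. Going by the values given here, no measured step covers an exchange of this kind: the one known step concerns adding a methoxy, not replacing the whole aryl group attached to the sulfonyl oxygen. Going by these compounds, that step shows the aryl portion is sensitive to substitution, but its direction for a 4-chlorophenyl is untested. The expectation is a change of no more than the usual scatter, in either direction, so a 1.1-fold lower number from compound 1 to compound 3 (0.03 log units; within the scatter) is the estimated step. Compound 3 is accordingly estimated at 1500 nM, within 500 nM to 4500 nM.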

Compound 3, half-maximal inhibitory concentration: 43000 nM
Estimate against measurement, compound 3: 29-fold (1.46 log units) below, and the stated range ends below it.
By their numbers in this assay, from the lowest: compound 1; then compound 2; then compound 3.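

In this assay the aryl group on the oxygen bonded to the sulfonyl sulfur tolerates this exchange far less well than the earlier step suggested: 4-chlorophenyl in place of 3-methoxyphenyl is a large loss (a 27-fold higher number from compound 1 to compound 3 (1.43 log units; beyond the scatter)), against a modest one for the added methoxy (a 5.3-fold higher number from compound 1 to compound 2 (0.73 log units; beyond the scatter)). Both changes at this aryl group raise the number, so compound 1 remains the lowest of the three, with its steps to both others beyond the scatter. Nothing available accounts for the size of this step.

The compounds shown do not separate the loss of the methoxy from the arrival of the chlorine, which 3-chlorophenyl, 4-methoxyphenyl or plain phenyl would do. Going by these compounds, whether an amine or a carboxylic acid on this aryl group would give a lower number than compound 1 also stays open.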